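The source may report more compounds than this note shows. Statements on the series, on what has been measured and on what is new or still open speak of the compounds shown alone.

The study covers four compounds. Compound 1 `CCCC1CCC(OC(=O)N[C@@H](CC(C)C)C(=O)N[C@H](C=O)C[C@@H]2CCNC2=O)CC1` was tested in a toxicity assay on Huh-7 cells (Homo sapiens) for cytotoxicity; a lower number here means that less compound is tolerated, a higher number that more compound is tolerated. In this assay compound 1 reaches only a limit, > 100000 nM. Compound 2 `CC(C)C[C@H](NC(=O)OC1CCC(F)(F)CC1)C(=O)N[C@H](C=O)C[C@@H]1CCNC1=O` differs from compound 1 by 4,4-difluorocyclohexyl in place of 4-propylcyclohexyl on an oxygen next to a carbonyl group. In this assay compound 2 likewise stops at a limit, > 100000 nM. The step that the two limits leave unreadable from compound 1 to compound 2 cannot be sized because of the limit of > 100000 nM in this assay, at which 3 of the 3 values shown sit. Compound 3 `CCCC1CCC(OC(=O)N[C@@H](CC(C)C)C(=O)N[C@@H](C[C@@H]2CCNC2=O)C(O)S(=O)(=O)O)CC1` differs from compound 1 by hydroxy(sulfo)methyl in place of formyl on a saturated chain carbon bound to an amide-type nitrogen and a saturated chain carbon, which is how the two cores differ. In this assay compound 3 also stands at a limit, > 100000 nM. The step that the two limits leave unreadable from compound 1 to compound 3 is equally unreadable. Compound 4 `CC(C)C[C@H](NC(=O)OC1CCC(F)(F)CC1)C(=O)N[C@@H](C[C@@H]1CCNC1=O)C(O)S(=O)(=O)O` differs from compound 3 by 4,4-difluorocyclohexyl in place of 4-propylcyclohexyl on an oxygen next to a carbonyl group, the same change as from compound 1 to compound 2, at a place worded identically. Since the limit of > 100000 nM in this assay, at which 3 of the 3 values shown sit, holds for every value shown, the step of a number no higher from compound 3 to compound 4 (the limit leaves the size open) is expected to be small. Compound 4 is expected to give 100000 nM.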

Compound 4, half-maximal cytotoxic concentration: > 100000 nM
Compound 4 was reported as a limit (the forecaster's own chance of this, stated with the estimate: 90%); the middle value lies on the limit itself.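

Compound 4 is reported only as a limit, > 100000 nM. Its steps from compound 2 and compound 3 therefore cannot be read: the limit of > 100000 nM in this assay, at which 4 of the 4 values shown sit.

The compounds shown leave open what concentration produces half-maximal cytotoxicity for any of the four compounds in this assay, and whether either change alters it.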